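The source may hold more compounds than are shown below. What is called first, only, known or untested is meant among the compounds shown, and "the series" means these compounds.

Compound 3, `CC(c1ccc(-c2ccccc2)c(F)c1)c1nnc2n1N=C(c1ccc(Br)cc1)CS2`, gives 3700 nM in a functional assay on HepG2 cells (Homo sapiens) for inhibition, read by sulforhodamine B assay, with a stated time of 72 h; a lower number here means a stronger inhibitor, a higher number a weaker inhibitor. Among the three compounds measured so far, compound 3 holds the lowest number. Compound 2, `COc1ccc(C2=Nn3c(nnc3C(C)c3ccc(-c4ccccc4)c(F)c3)SC2)cc1`, gives 4200 nM in this assay, and the gap a 1.1-fold lower number from compound 2 to compound 3 (0.06 log units; within the scatter) lies within the scatter, so the two cannot be ordered. Compound 1, `CC(c1ccc(-c2ccccc2)c(F)c1)c1nnc2n1N=C(c1ccc(Cl)cc1Cl)CS2`, gives 8600 nM in this assay, and its gaps to the other two, a 2.0-fold lower number from compound 1 to compound 2 (0.31 log units; beyond the scatter) and a 2.3-fold lower number from compound 1 to compound 3 (0.37 log units; beyond the scatter), are both modest but beyond the scatter.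

Compound 4, `CC(c1ccc(-c2ccccc2)c(F)c1)c1nnc2n1N=C(c1ccc([N+](=O)[O-])cc1)CS2`, is not yet measured. It differs from compound 3 by a single change: nitro in place of bromo on an aromatic carbon. Within the data shown here, the one measured step that bears on this position is a 1.1-fold lower number from compound 2 to compound 3 (0.06 log units; within the scatter), an exchange of one group on the same aromatic carbon, para to a large group, which produced no shift beyond the scatter. The two larger steps, from compound 1, involved replacing the whole 2,4-dichlorophenyl and do not speak to a swap at this one carbon.

On that basis the step of a 1.1-fold higher number from compound 3 to compound 4 (0.03 log units; within the scatter) is expected to stay within the scatter. Compound 4 is therefore estimated at 4000 nM in this assay, with a range from 1500 nM to 11000 nM.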

Compound 4, half-maximal inhibitory concentration: 4300 nM
Beside the measured number, compound 4's estimate is 1.1-fold (0.03 log units) below it; measured number inside the range.
By their numbers in this assay, from the lowest: compounds 3, 2, 4 and 1 (each within the scatter of the next, the first and the last beyond it).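

On the aromatic carbon para to a large group, nitro in place of bromo gives a 1.2-fold higher number from compound 3 to compound 4 (0.07 log units; within the scatter) in this assay and nitro in place of methoxy gives a 1.0-fold higher number from compound 2 to compound 4 (0.01 log units; within the scatter) in the same assay, so bromo, methoxy and nitro now all lie within the scatter of one another at this carbon. Among these compounds, this extends the single earlier exchange at this position to a third group, one that differs from bromo in size and in its count of hydrogen-bond acceptors, and the number still does not separate them. The 4-nitrophenyl in place of 2,4-dichlorophenyl, a 2.0-fold lower number from compound 1 to compound 4 (0.30 log units; within the scatter) and so within the scatter, also shows that compound 1 is not set apart from every compound with a single group at this carbon, although a 2.0-fold lower number from compound 1 to compound 2 (0.31 log units; beyond the scatter) and a 2.3-fold lower number from compound 1 to compound 3 (0.37 log units; beyond the scatter) are printed as beyond it, and no measurement at hand accounts for any of these steps.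

As far as these compounds go, whether this flat picture holds for an amine, a carboxylic acid or a longer alkyl chain on this carbon remains open, as does the plain phenyl with hydrogen there. From the compounds shown here alone, it is also open whether the 2-chloro or the 4-chloro of the 2,4-dichlorophenyl alone would shift the number in this assay at all.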